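The compounds below may be only part of what the source reports. "The series", "measured", "known", "first", "only" and "open" are said of these compounds alone.

Among the measured compounds shown here, in an ADME assay on liver for metabolic stability, with Liver microsome (Homo sapiens) as the target, using microsomes (a higher number here means faster removal of the compound, a lower number slower removal), compound 1 (`CCN(CCN)c1ccc(Nc2cc(NC3CC3)n3ncc(C#N)c3n2)cc1NC(C)=O`) gives 5 mL.min-1.g-1 and compound 2 (`CC(=O)Nc1cc(Nc2cc(NC3CC3)n3ncc(C#N)c3n2)ccc1N1CCC[C@@H](N(C)C)C1`) gives 19 mL.min-1.g-1 as the higher of the two numbers so far. For the measured compounds named here, the only measured step (a 3.8-fold higher number from compound 1 to compound 2 (0.58 log units; beyond the scatter)) replaces a whole group on an aromatic carbon, so it bears only loosely on the next change. Compound 3 (`CC(=O)Nc1cc(Nc2cc(NC3CC3)n3ncc(C#N)c3n2)ccc1N1CCC[C@@H](N)C1`) differs from compound 2 by a smaller edit (amino in place of dimethylamino on a saturated ring carbon), amino in place of dimethylamino on a saturated ring carbon. Going by the values given here, no measured pair isolates this edit. Compound 1 with its 5 mL.min-1.g-1 also carries an amino group, so a fall seems likelier than a rise, and it should be smaller than the measured step. The expected step (a 2.1-fold lower number from compound 2 to compound 3 (0.32 log units; beyond the scatter)) is therefore a modest one towards a lower number, near the edge of the scatter. For compound 3 the estimated value is 9 mL.min-1.g-1 within an expected range from 4 mL.min-1.g-1 to 18 mL.min-1.g-1 in this assay.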

Compound 3, intrinsic clearance in microsomes: < 3 mL.min-1.g-1
Compound 3 was reported as a limit; the forecaster's own chance of this, stated with the estimate: 5%; at least 3.0-fold (0.47 log units) between middle value and limit.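

In this assay, compound 3 stands at a limit and not at a number: the limit of < 3 mL.min-1.g-1 in this assay, at which 1 of the 3 values shown sits. Amino in place of dimethylamino on this saturated ring carbon gives an at least 6.3-fold lower number from compound 2 to compound 3 (0.80 log units; beyond the scatter), so an edit at this one ring carbon, with the rest of the molecule unchanged, is enough to carry the number beyond the scatter. Exchanging the whole group on the aromatic carbon gives an at least 1.6-fold lower number from compound 1 to compound 3 (0.22 log units; that floor lies within the scatter), and as that floor lies within the scatter, this pair cannot be put in a firm order.

From the compounds shown here alone, whether methylamino, with a single methyl on the nitrogen, would sit nearer compound 2 or compound 3 remains open. Also open, going by these compounds, are how far the true number of compound 3 lies under its limit and whether dimethylamino on the open chain of compound 1 would shift the number in the same way.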